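Bromo for nitro on a naphthyloxyacetyl hydrazone

A few compounds are considered here, and "the series" means these few. Any claim that something is new, unique, unknown or untested is made for them only; others in the source may bear on it.

Measured so far in an ADME assay on MT4 cells (Homo sapiens) for cytotoxicity, read by MTT assay, with a stated time of 4 days; on this read-out higher numbers stand for lower toxicity in this test and lower numbers for higher toxicity in this test:
compound 1, `O=C(COc1cccc2ccccc12)N/N=C/c1cccc([N+](=O)[O-])c1`: 12.1 ug/mL
compound 2, `C/C(=N\NC(=O)COc1cccc2ccccc12)c1ccc([N+](=O)[O-])cc1`: 89.3 ug/mL

Compound 1 holds the lowest of the two numbers; compound 2, its nearest neighbour, stands higher by a margin beyond the usual scatter, and the two differ in more than one place, so no single step can be read between them.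

The unmeasured compound 3, `O=C(COc1cccc2ccccc12)N/N=C/c1cccc(Br)c1`, is derived from compound 1 by one change: bromo in place of nitro on an aromatic carbon. The bromo group carries no hydrogen-bond acceptors where the nitro group carried two, and the exchange sits on the six-membered aromatic ring of carbon only.

Among the compounds with values here, no measured pair shows what this exchange does in this assay. The step from compound 1 to compound 3 is expected to be small, likely within the scatter or a slight move upward, as a 1.5-fold higher number from compound 1 to compound 3 (0.17 log units; within the scatter). Compound 3 is therefore estimated at 18 ug/mL, with a range from 6 ug/mL to 55 ug/mL.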

Compound 3, half-maximal cytotoxic concentration: 87.4 ug/mL
Compound 3: middle estimate off by 4.9-fold (0.69 log units), on the low side; measured number above the stated range.
By their numbers in this assay, from the lowest: compound 1; then compounds 3 and 2 (each within the scatter of the next).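

In this assay the exchange of nitro for bromo gives a 7.2-fold higher number from compound 1 to compound 3 (0.86 log units; beyond the scatter) and so supplies the first single-place comparison among these compounds. It shows that this place, on an aromatic carbon meta to a large group, is not indifferent to its substituent, since this one change moves the number beyond the scatter towards lower toxicity in this test. No evidence here bears on why the exchange has this effect.

With only bromo and nitro shown at this place, it remains open whether an amine, a methoxy group or a carboxylic acid there would stand with compound 1 or with compound 3. Also open, on these data alone, is whether the same exchange would give a similar step at another place on the aromatic ring.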